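The source may report more compounds than this note shows. Statements on the series, on what has been measured and on what is new or still open speak of the compounds shown alone.

In a functional assay on PC-3 cells (Homo sapiens) for inhibition, read by MTT assay, with a stated time of 48 h (on this read-out higher numbers stand for weaker inhibition and lower numbers for stronger inhibition), compound 1 `COc1ccc(CSc2nnc(-c3cc(OC)c(OC)c(OC)c3)n2-c2ccc(OC)cc2)cc1` gives 40300 nM and compound 2 `COc1cc(-c2nnc(SCc3ccccc3)n2-c2ccc(N(C)C)cc2)cc(OC)c1OC` gives 55800 nM, two values within the scatter of each other. Compound 3 `COc1ccc(CSc2nnc(-c3cc(OC)c(OC)c(OC)c3)n2-c2ccc(N(C)C)cc2)cc1` reads > 60000 nM, which is a limit of the assay and not a number. Its standing on the numbers shown is therefore only this: the limit of > 60000 nM in this assay, at which 1 of the 3 values shown sits.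

The two measured steps into compound 3 are an at least 1.4-fold higher number from compound 1 to compound 3 (0.17 log units; that floor lies within the scatter) and an at least 1.0-fold higher number from compound 2 to compound 3 (0.03 log units; that floor lies within the scatter). Both floors lie within the scatter, so neither step gives a size that can be carried forward.

Compound 4 `COc1cc(-c2nnc(SCC(=O)c3ccc(F)cc3)n2-c2ccc(N(C)C)cc2)cc(OC)c1OC` keeps the dimethylamino group of compound 3 and differs from it as follows: (4-fluorophenyl)carbonyl in place of 4-methoxyphenyl on a saturated chain carbon bound to a sulfur. In the wider reading, 4-methoxybenzyl gives way to ((4-fluorophenyl)carbonyl)methyl. For the measured compounds named here, the nearest measured change is the methoxy in place of hydrogen on an aromatic carbon, in an at least 1.0-fold higher number from compound 2 to compound 3 (0.03 log units; that floor lies within the scatter), and no measured step involves the carbonyl. As far as these compounds go, on that basis, no step beyond the scatter is expected in this assay, and the direction stays open. The estimated change is an at least 1.3-fold lower number from compound 3 to compound 4 (0.12 log units; that floor lies within the scatter), and a reading at the limit of the assay would be no surprise. Compound 4 is estimated at 45000 nM, with an expected range of 15000 nM to 80000 nM.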

Compound 4, half-maximal inhibitory concentration: 42300 nM
Compound 4: middle estimate off by 1.1-fold (0.03 log units), on the high side; low and high end bracket the measured number.
By their numbers in this assay, from the lowest: compounds 1, 4 and 2 (each within the scatter of the next). At a limit, above all of these: compound 3.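

In this assay, (4-fluorophenyl)carbonyl in place of phenyl on a saturated chain carbon bound to a sulfur gives a 1.3-fold lower number from compound 2 to compound 4 (0.12 log units; within the scatter), so this position takes a carbonyl and a fluorine with no step beyond the scatter. The same group in place of 4-methoxyphenyl gives an at least 1.4-fold lower number from compound 3 to compound 4 (0.15 log units; that floor lies within the scatter), a step that starts from a limit and gives no size that can be carried forward. Compound 3 still stands at a limit of the assay and not at a number: the limit of > 60000 nM in this assay, at which 1 of the 4 values shown sits.

As far as these compounds go, whether an amine, a carboxylic acid or a longer chain at this saturated chain carbon bound to a sulfur would give a step beyond the scatter stays open. The carbonyl and the fluorine enter together in compound 4, so the compounds shown do not separate them, and a plain phenylcarbonyl group or a 4-fluorobenzyl group would be needed to read each one alone.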